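Cyano in place of fluoro: compound 3 to compound 4

This account rests on a few compounds, and the source may have more. Where it says the series, first, only, none or still open, it means among the compounds named here.

Measured so far in a functional assay on A549 cells (Homo sapiens) for antiproliferative activity, read by XTT assay, with a stated time of 24 h; on this read-out higher numbers stand for weaker inhibition and lower numbers for stronger inhibition:
compound 1 `Fc1ccc(C2CC(c3ccc(Cl)s3)=NN2c2nc(-c3ccccc3)cs2)cc1` gives > 500 ug/mL, a limit of the assay.
compound 2 `Cc1ccc(C2=NN(c3nc(-c4ccc(Cl)cc4)cs3)C(c3ccc(F)cc3)C2)s1` gives > 500 ug/mL, a limit of the assay.
compound 3 `Cc1ccc(C2=NN(c3nc(-c4ccc(F)cc4)cs3)C(c3ccc(F)cc3)C2)s1` gives 125 ug/mL.

Going by the values given here, compound 3 is thus the only member of the set with a number in this assay; the two remaining values sit at the limit of > 500 ug/mL in this assay, at which 2 of the 3 values shown sit. Among the compounds with values here, the only step measured between neighbours is an at least 4.0-fold lower number from compound 2 to compound 3 (0.60 log units; beyond the scatter). Compound 4 `Cc1ccc(C2=NN(c3nc(-c4ccc(C#N)cc4)cs3)C(c3ccc(F)cc3)C2)s1` changes compound 3 by cyano in place of fluoro on an aromatic carbon. Within the data shown here, no measured step exchanges fluoro for cyano, and the single step available concerns a different pair of groups, so it gives no direction for this change. Compound 4 is therefore expected near compound 3, with the step of a 1.2-fold higher number from compound 3 to compound 4 (0.08 log units; within the scatter) estimated as within the scatter, and it is also possible that the expected value turns out to be only a limit of the assay. For compound 4 the estimated value is 150 ug/mL (range 40 ug/mL to 500 ug/mL).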

Compound 4, half-maximal inhibitory concentration: 322 ug/mL
Compound 4: the middle estimate sits 2.1-fold (0.33 log units) below what was measured; the measured number falls inside the stated range.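

In this assay the change from 4-fluorophenyl to 4-cyanophenyl, para to a large group, gives a 2.6-fold higher number from compound 3 to compound 4 (0.41 log units; beyond the scatter), so cyano does not match fluoro at this position. Compound 3, with fluoro, now has the lowest number of the three groups tried here. Against chloro, the reading is only an at least 1.5-fold lower number from compound 2 to compound 4 (0.19 log units; that floor lies within the scatter), which leaves cyano and chloro unordered because compound 2 holds a limit of the assay: the limit of > 500 ug/mL in this assay, at which 2 of the 4 values shown sit.

On these data alone, whether an amine or a methoxy group here would fall below compound 3 stays open. So does whether fluoro keeps its lead with other groups elsewhere on the shared core.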